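Swapping the amine substituent in a weak cell inhibitor

This account rests on a few compounds, and the source may have more. Where it says the series, first, only, none or still open, it means among the compounds named here.

Compound 1 `c1ccc(COc2ccc(OCCOCCNc3ccncc3)cc2)cc1`: 20600 nM
Compound 2 `COc1ccc(COc2ccc(OCCOCCNC3CCCC3)cc2)cc1`: 15700 nM
Compound 3 `O=[N+]([O-])c1cccc(COc2ccc(OCCOCCNC3CCCC3)cc2)c1`: 15400 nM

All three compounds share one core and were tested in a functional assay on SK-OV-3 cells (Homo sapiens) for inhibition, read by CCK-8 assay, with a stated time of 70 h; on this read-out higher numbers stand for weaker inhibition and lower numbers for stronger inhibition. Compound 1 carries the highest of the three numbers, but its gaps to compound 2 and to compound 3 both lie within the scatter, so the three cannot be put in order. For the measured compounds named here, the only step between compounds that differ in a single place is a 1.0-fold lower number from compound 2 to compound 3 (0.01 log units; within the scatter), which changes the group on a saturated chain carbon bound to an oxygen on an aromatic ring and says nothing about the amine nitrogen.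

Compound 4 `c1ccc(COc2ccc(OCCOCCNC3CCC3)cc2)cc1` differs from compound 1 by cyclobutyl in place of pyridin-4-yl on an amine nitrogen. Going by the values given here, compounds 2 and 3 have another group on that nitrogen and also differ from compound 1 elsewhere, so no single step links them to compound 1; their values merely sit close to that of compound 1. Among the compounds with values here, no measured step therefore bears directly on this change, and no step beyond the scatter is expected: compound 4 is estimated to show a 1.1-fold lower number from compound 1 to compound 4 (0.06 log units; within the scatter). Compound 4 is expected at 18000 nM, with a range from 8000 nM to 40000 nM.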

Compound 4, half-maximal inhibitory concentration: 25000 nM
For compound 4 the middle estimate is 1.4-fold (0.14 log units) below the measured one, within the range that was stated.
By their numbers in this assay, from the lowest: compounds 3, 2, 1 and 4 (each within the scatter of the next).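

For the compounds shown here, this is the first direct reading of a change on the amine nitrogen: in this assay, cyclobutyl in place of pyridin-4-yl gives a 1.2-fold higher number from compound 1 to compound 4 (0.08 log units; within the scatter). The group that leaves is a six-membered aromatic ring with one hetero atom and the group that enters is a four-membered non-aromatic ring of carbon only, yet the two cannot be told apart on this read-out. No available measurement offers a reason for this result.

Going by these compounds alone, whether any group on this nitrogen can move the number beyond the scatter remains open, as the only direct comparison here is between these two rings. A morpholine ring, a longer alkyl chain or a chain ending in a carboxylic acid on the same nitrogen of the shared core would test this further.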